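A few compounds are considered here, and "the series" means these few. Any claim that something is new, unique, unknown or untested is made for them only; others in the source may bear on it.

Measured so far in an ADME assay on ECV-304 cells (Homo sapiens) for cytotoxicity, read by MTT assay, with a stated time of 72 h; on this read-out lower numbers stand for stronger inhibition and higher numbers for weaker inhibition:
compound 1 `COc1ccc(C2=C(c3cc(OC)c(OC)c(OC)c3)C(=O)C(OC(C)=O)C2)cc1OC(C)C` gives > 100 ug/mL
compound 2 `COc1cc(C2=C(c3cc(C)c(OC)c(C)c3)C(O)CC2=O)cc(OC)c1OC` gives > 100 ug/mL
compound 3 `COc1ccc(C2=C(c3cc(OC)c(OC)c(OC)c3)C(=O)C(O[SiH2]C(C)(C)C)C2)cc1OC(C)C` gives > 100 ug/mL

In this set, compound 1 gives > 100 ug/mL, which is a limit of the assay and not a number. It has no company at any readable value: the limit of > 100 ug/mL in this assay, at which 3 of the 3 values shown sit. Going by the values given here, the only measured comparison with a single change is a step that the two limits leave unreadable from compound 1 to compound 3, and that change sits on an oxygen on a saturated carbon, so it is not the change at issue here.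

Compound 4 `COc1ccc(C2=C(c3cc(OC)c(OC)c(OC)c3)C(=O)C(OC(C)=O)C2)cc1O` keeps the rest of compound 1 and alters one group: hydrogen in place of isopropyl on an oxygen on an aromatic ring. Put simply, isopropoxy becomes hydroxy. Among the compounds with values here, no measured step covers this change, so the data offer no size to carry over. With compound 1 at > 100 ug/mL, the only movement that could be read for compound 4 is toward lower numbers, meaning stronger inhibition, though the reading may also stay at the limit. The expected size is an at least 10-fold lower number from compound 1 to compound 4 (1.00 log units; beyond the scatter), a rough estimate with wide margins. For compound 4 the expected value is 10 ug/mL, with an estimated range from 0.3 ug/mL to 100 ug/mL.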

Compound 4, half-maximal inhibitory concentration: > 100 ug/mL
Compound 4: only a limit was reported; the forecaster's own chance of this, stated with the estimate: 35%; middle value at least 10-fold (1.00 log units) away from the limit.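

In this assay compound 4 gives > 100 ug/mL, which is a limit of the assay and not a number. Compound 1 also stands at a limit, so no step can be read for isopropoxy becoming hydroxy between compound 1 and compound 4. The compounds shown leave open how far each lies past that limit and which change would give a readable value: the limit of > 100 ug/mL in this assay, at which 4 of the 4 values shown sit.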